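The source may report more compounds than this note shows. Statements on the series, on what has been measured and on what is new or still open speak of the compounds shown alone.

Of the compounds shown here, two have so far been tested in a functional assay on RXF 393 cells (Homo sapiens) for antiproliferative activity, read by sulforhodamine B assay, with a stated time of 48 h; on this read-out higher numbers stand for weaker inhibition of growth and lower numbers for stronger inhibition of growth. Compound 1 `COc1ccc(OC)c(/C=C/c2nnc(Nc3ccc(Cl)cc3)o2)c1` gives 2710 nM, whereas compound 2 `COc1ccc(OC)c(/C=C/C(=O)N/N=C/c2ccc(Cl)cc2)c1` gives 46.9 nM, the lowest of the two numbers and beyond the scatter from compound 1. Compound 3 `COc1ccc(OC)c(/C=C/C(=O)N/N=C/c2ccccc2)c1` differs from compound 2 by hydrogen in place of chloro on an aromatic carbon. Among the measured compounds shown here, no measured pair matches this change, so its size is uncertain. The expected step in this assay, a 1.8-fold higher number from compound 2 to compound 3 (0.26 log units; within the scatter), is a modest move toward weaker inhibition of growth. Compound 3 is accordingly estimated at 85 nM, with a range from 25 nM to 300 nM.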

Compound 3, concentration for 50% growth inhibition: 3900 nM
The estimate for compound 3 lay 46-fold (1.66 log units) below the measured number; the measured number lies above the stated range.
By their numbers in this assay, from the lowest: compound 2; then compounds 1 and 3 (each within the scatter of the next).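

In this assay, the position on the aromatic carbon para to a large group proves highly sensitive to this change: going from 4-chlorophenyl to phenyl, a swap of one chlorine atom for hydrogen, gives an 83-fold higher number from compound 2 to compound 3 (1.92 log units; beyond the scatter). Within this pair, the chloro group is therefore tied to much stronger inhibition of growth. No measurement at hand bears on the reason for this step. On these data alone, whether fluoro, bromo, methyl or an amine at the same place would match chloro stays open. So does whether the same change would carry similar weight on the core of compound 1.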